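The source may hold more compounds than are shown below. What is called first, only, known or untested is meant among the compounds shown, and "the series" means these compounds.

Among the three compounds measured in an assay on CHO cells for agonist activity at Free fatty acid receptor 1 (Homo sapiens), read by luminescence, with a stated time of 20 s, in the presence of a further agent that is not named here (a lower number here means that less compound is needed, a higher number that more compound is needed for the effect), compound 1 `Cc1cc(Cl)ccc1-c1cccc(COc2ccc([C@H](CC(=O)O)c3nccn3C)cc2)c1` stands lowest, giving 10000 nM. Compound 2 `Cc1cc(F)ccc1-c1cccc(COc2ccc([C@H](CC(=O)O)c3nccn3C)cc2)c1` gives 21000 nM, and compound 3 `Cn1ccnc1[C@@H](CC(=O)O)c1ccc(OCc2cccc(-c3ccc(Cl)cc3Cl)c2)cc1` gives 30000 nM. The step from compound 1 to compound 2, fluoro in place of chloro on an aromatic carbon, is a 2.1-fold higher number from compound 1 to compound 2 (0.32 log units; beyond the scatter); the step from compound 1 to compound 3, chloro in place of methyl on an aromatic carbon, is a 3.0-fold higher number from compound 1 to compound 3 (0.48 log units; beyond the scatter).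

Compound 4 `Cc1cccc(C)c1-c1cccc(COc2ccc([C@H](CC(=O)O)c3nccn3C)cc2)c1` differs from compound 1 as follows: 2,6-dimethylphenyl in place of 4-chloro-2-methylphenyl on an aromatic carbon. Both earlier steps bear on this change, since one removes the chloro and the other shows that methyl did better than chloro at the place where it sat. These pull in opposite directions, so only a modest shift is expected, most likely toward a higher number because removing the chloro in the step from compound 1 to compound 2 gave a 2.1-fold higher number from compound 1 to compound 2 (0.32 log units; beyond the scatter). Compound 4 is therefore estimated at 18000 nM in this assay, within a range of 6000 nM to 55000 nM, a step of a 1.8-fold higher number from compound 1 to compound 4 (0.26 log units; within the scatter).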

Compound 4, half-maximal effective concentration: 29000 nM
Beside the measured number, compound 4's estimate is 1.6-fold (0.21 log units) below it; the range from low to high includes it.
By their numbers in this assay, from the lowest: compound 1; then compounds 2, 4 and 3 (each within the scatter of the next).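

Replacing 4-chloro-2-methylphenyl with 2,6-dimethylphenyl gives a 2.9-fold higher number from compound 1 to compound 4 (0.46 log units; beyond the scatter) in this assay, so moving the second methyl onto the ring in place of the chloro does not keep the number of compound 1. The comparisons a 1.4-fold higher number from compound 2 to compound 4 (0.14 log units; within the scatter) and a 1.0-fold lower number from compound 3 to compound 4 (0.01 log units; within the scatter) both stay within the usual scatter, so compound 4 cannot be told apart from compound 2 or compound 3. Among these four compounds, compound 1 alone stands clear, with each of the other three aromatic groups giving a higher number beyond the scatter.

Whether a methoxy, trifluoromethyl or amine group on this ring could bring the number below that of compound 1 remains open, and nothing shown here explains why these numbers shift.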